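Aryl group and liver microsome clearance in the sulfone series

The source may hold more compounds than are shown below. What is called first, only, known or untested is meant among the compounds shown, and "the series" means these compounds.

Among the measured compounds shown here, compound 3 `COc1ccc(-c2c(S(=O)(=O)c3cc(F)cc(F)c3)cnc3c(F)cccc23)cc1` carries the highest number among the three measured members in an ADME assay on microsomes from liver (Homo sapiens) for metabolic stability, tested at 2.5 uM; a lower number here means slower removal, a higher number faster removal of the compound: compound 3 gives 2.59 mL/min, compound 2 `O=S(=O)(c1cc(F)cc(F)c1)c1cnc2c(F)cccc2c1-c1cccc(Cl)c1` gives 0.64 mL/min, and compound 1 `O=S(=O)(c1cc(F)cc(F)c1)c1cnc2c(F)cccc2c1-c1ccccc1F` gives 0.09 mL/min. The steps of a 7.1-fold higher number from compound 1 to compound 2 (0.85 log units; beyond the scatter), a 29-fold higher number from compound 1 to compound 3 (1.46 log units; beyond the scatter) and a 4.0-fold higher number from compound 2 to compound 3 (0.61 log units; beyond the scatter) all lie beyond the scatter, so the group on this aromatic carbon plainly moves the read-out. Compound 4 `COc1cccc(-c2c(S(=O)(=O)c3cc(F)cc(F)c3)cnc3c(F)cccc23)c1` differs from compound 3 by 3-methoxyphenyl in place of 4-methoxyphenyl on an aromatic carbon. For the measured compounds named here, no measured step bears directly on this change, since each measured step exchanges one group for another, whereas here the same atoms are joined differently. The spread among compounds 1, 2 and 3 only shows the read-out to be sensitive at this position. A modest downward step is expected, a 1.7-fold lower number from compound 3 to compound 4 (0.24 log units; within the scatter). Compound 4 is therefore estimated at 1.5 mL/min, within 0.6 mL/min to 3.5 mL/min.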

Compound 4, intrinsic clearance in a liver preparation (reported as CLH), per the amount of preparation that the assay uses: 2.76 mL/min
For compound 4 the middle estimate is 1.8-fold (0.26 log units) below the measured one; the range from low to high includes it.
By their numbers in this assay, from the lowest: compound 1; then compound 2; then compounds 3 and 4 (each within the scatter of the next).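

Exchanging 4-methoxyphenyl for 3-methoxyphenyl gives no resolved difference in this assay, with a 1.1-fold higher number from compound 3 to compound 4 (0.03 log units; within the scatter), so the read-out does not separate these two attachments of the methoxy group. Both methoxyphenyl compounds stand apart from the halogenated aryl compounds, as compound 4 shows with a 4.3-fold higher number from compound 2 to compound 4 (0.63 log units; beyond the scatter) and a 31-fold higher number from compound 1 to compound 4 (1.49 log units; beyond the scatter). No data bearing on the reason for this separation are available. On these data alone, whether a hydroxy group, an amine or a longer ether chain in place of methoxy would stay with compounds 3 and 4 remains open.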